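The source may report more compounds than this note shows. Statements on the series, on what has been measured and on what is new or still open speak of the compounds shown alone.

In a functional assay on AGS cells (Homo sapiens) for inhibition, read by reporter gene assay (on this read-out higher numbers stand for weaker inhibition and lower numbers for stronger inhibition), compound 1 `CC(C)(C)c1ccc(OCC(=O)Nc2cccc(C(=O)O)c2)cc1` gives 9500 nM. Compound 2 `O=C(COc1ccc(F)cc1)Nc1cccc(C(=O)O)c1` reads > 30000 nM, which is a limit and not a number. Compound 3 `NC(=O)c1cccc(NC(=O)COc2ccc([N+](=O)[O-])cc2)c1` reads > 30000 nM, also a limit. Compound 2 therefore has no number of its own: the limit of > 30000 nM in this assay, at which 2 of the 3 values shown sit.

Compound 4 `COc1cccc(-c2ccc(OCC(=O)Nc3cccc(C(=O)O)c3)cc2)c1` carries 3-methoxyphenyl in place of fluoro on an aromatic carbon, with 3-methoxyphenyl in place of fluoro on an aromatic carbon, para to a large group. Within the data shown here, the one measured step bearing on this change is an at least 3.1-fold higher number from compound 1 to compound 2 (0.49 log units; beyond the scatter), beyond the scatter. It shows fluoro giving the higher reading against tert-butyl, so a larger group in place of fluoro is expected to give a lower number in this assay, beyond the scatter. The expected step is an at least 6.0-fold lower number from compound 2 to compound 4 (0.77 log units; beyond the scatter). Compound 4 is estimated at 5000 nM, with an expected range from 1500 nM to 18000 nM.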

Compound 4, half-maximal inhibitory concentration: 35000 nM
Compound 4: the middle estimate sits 7.0-fold (0.85 log units) below what was measured; the whole stated range lies below it.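

In this assay, a large group on this aromatic carbon does not by itself bring the number down: 3-methoxyphenyl in place of tert-butyl gives a 3.7-fold higher number from compound 1 to compound 4 (0.57 log units; beyond the scatter). Of this pair, tert-butyl keeps the lower reading, so the trend from fluoro to tert-butyl does not extend to every larger group. The step from compound 2 to compound 4 cannot be read, since compound 2 holds only a limit: the limit of > 30000 nM in this assay, at which 2 of the 4 values shown sit.

Still open, as far as these compounds go, is how an amine or a cyclohexyl group on this carbon would read against tert-butyl. Also open, from the compounds shown here alone, is whether the reading of compound 4 follows from the methoxy group or from the phenyl ring itself.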